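The source may hold more compounds than are shown below. What is called first, only, known or untested is meant among the compounds shown, and "the series" means these compounds.

Compound 1 `Nc1nc(N)c2cc(CSC(=S)N3CCN(C4CCCCC4)CC3)ccc2n1`: 4050 nM
Compound 2 `Nc1nc(N)c2cc(CSC(=S)N3CCN(c4ccc(Cl)c(Cl)c4)CC3)ccc2n1`: 3480 nM

Both values come from a functional assay on HT-29 cells (Homo sapiens) for antiproliferative activity, read by MTT assay, with a stated time of 72 h; a lower number here means a stronger inhibitor, a higher number a weaker inhibitor. Among the compounds with values here, with only two compounds measured, compound 2 stands level with compound 1 once the usual scatter of repeated measurements is allowed for. The next compound, compound 3 `Nc1nc(N)c2cc(CSC(=S)N3CCN(c4ccc([N+](=O)[O-])cc4)CC3)ccc2n1`, differs from compound 2 in one place, with 4-nitrophenyl in place of 3,4-dichlorophenyl on an amine nitrogen in a ring.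

Within the data shown here, one measured step bears on this change, since it altered the same place, with 3,4-dichlorophenyl replacing cyclohexyl. That step is a 1.2-fold lower number from compound 1 to compound 2 (0.07 log units; within the scatter). Among the measured compounds shown here, one step is thin evidence, and no compound carrying 4-nitrophenyl has yet been measured, so the range must stay wide. Starting from compound 2 at 3480 nM, no change beyond the scatter is expected in this assay, and no direction can be favoured.

The expected step is a 1.0-fold higher number from compound 2 to compound 3 (0.01 log units; within the scatter). The estimate for compound 3 is 3600 nM, with an expected range of 1600 nM to 8000 nM.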

Compound 3, half-maximal inhibitory concentration: 3320 nM
For compound 3 the middle estimate is 1.1-fold (0.04 log units) above the measured one; the range from low to high includes it.
By their numbers in this assay, from the lowest: compounds 3, 2 and 1 (each within the scatter of the next).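

In this assay, placing 4-nitrophenyl where 3,4-dichlorophenyl stood gives a 1.0-fold lower number from compound 2 to compound 3 (0.02 log units; within the scatter), and placing it where cyclohexyl stood gives a 1.2-fold lower number from compound 1 to compound 3 (0.09 log units; within the scatter). The position on the amine nitrogen of the six-membered ring has now taken three different groups with no step beyond the scatter, and this includes a swap between two aromatic rings with different substituents, in which the incoming group brings hydrogen-bond acceptors that 3,4-dichlorophenyl lacks. No other measurement is available to explain why these three groups read alike.

The compounds shown leave open whether any group on this nitrogen can move the number beyond the scatter, such as a plain methyl, a longer chain ending in a carboxylic acid, or a primary amine. On these data alone, all three compounds also share the rest of their structure, so the effect of a change elsewhere in the shared core remains unknown.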